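The source may report more compounds than this note shows. Statements on the series, on what has been measured and on what is new or still open speak of the compounds shown alone.

Compound 2, with structure `COc1cccc(Nc2cc3[nH]c(-c4cccc(C(F)(F)F)c4)nc3cn2)n1`, is one of three measured analogues of a shared core in which a substituted pyridinyl group sits on a nitrogen on an aromatic ring. In an ADME assay on microsomes from liver (Rattus norvegicus) for metabolic stability, read by LC-MS, with a stated time of 30 min, tested at 0.1 uM (on this read-out lower numbers stand for a less stable compound and higher numbers for a more stable compound), compound 2 gives 49%, the highest of the three numbers. Compound 1 `FC(F)(F)c1cccc(-c2nc3cnc(Nc4ccccn4)cc3[nH]2)c1` gives 45%, and compound 3 `Fc1cnc(Nc2cc3[nH]c(-c4cccc(C(F)(F)F)c4)nc3cn2)c(F)c1` gives 43%. The gaps between them are small: a number 4 percentage points higher from compound 1 to compound 2 (within the scatter), a number 2 percentage points lower from compound 1 to compound 3 (within the scatter), and a number 6 percentage points lower from compound 2 to compound 3 (within the scatter). None of these differences exceeds the usual scatter, so the three compounds cannot be ordered by metabolic stability on this evidence.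

Compound 4 `N#Cc1ccc(Nc2cc3[nH]c(-c4cccc(C(F)(F)F)c4)nc3cn2)nc1` has not yet been measured. The change from compound 2 to compound 4 is 5-cyanopyridin-2-yl in place of 6-methoxypyridin-2-yl on a nitrogen on an aromatic ring.

The step that bears most directly on this change is the exchange of 6-methoxypyridin-2-yl for 3,5-difluoropyridin-2-yl on the same nitrogen, which gave only a number 6 percentage points lower from compound 2 to compound 3 (within the scatter), and the exchange of pyridin-2-yl for the 6-methoxypyridin-2-yl group gave only a number 4 percentage points higher from compound 1 to compound 2 (within the scatter). Every variation of the group on that nitrogen so far has left this assay essentially unchanged, so for compound 4 no step beyond the scatter is expected, and the estimate is a number 4 percentage points lower from compound 2 to compound 4 (within the scatter). Compound 4 is therefore expected to give 45% in this assay, with a range from 32% to 58%.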

Compound 4, percent of the compound remaining: 49%
The estimate for compound 4 lay 4 percentage points below the measured number; the range from low to high includes it.
By their numbers in this assay, from the lowest: compounds 3, 1, 2 and 4 (each within the scatter of the next).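

In this assay, going by these compounds alone, a cyano substituent on the pyridine ring, which no earlier compound carried, also leaves the reading within the scatter: no change at the digits printed from compound 2 to compound 4 (within the scatter), a number 6 percentage points higher from compound 3 to compound 4 (within the scatter) and a number 4 percentage points higher from compound 1 to compound 4 (within the scatter). The step from the unsubstituted pyridin-2-yl group now has a second single-substituent case, cyano in place of hydrogen, to set beside methoxy in place of hydrogen at a number 4 percentage points higher from compound 1 to compound 2 (within the scatter), so neither substituent separates from the parent group on this read-out, and among these four compounds no exchange at this position goes beyond the scatter. Nothing available accounts for this flat picture, and no measurement bears on what sets the stability of these compounds.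

As far as these compounds go, all four groups on this nitrogen are substituted or unsubstituted pyridin-2-yl rings, so it remains open whether a saturated ring such as morpholine or piperidine, or a carboxylic acid on the pyridine, would move the reading beyond the scatter. The compounds shown also leave open how the reading would respond to replacing the trifluoromethyl group, which all four share, with a group such as a methyl or a chlorine.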